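This account rests on a few compounds, and the source may have more. Where it says the series, first, only, none or still open, it means among the compounds named here.

Measured so far in an ADME assay on Raji cells (Homo sapiens) for cytotoxicity, read by CellTiter-Glo and resazurin assay, with a stated time of 72 h; a lower number here means that less compound is needed, a higher number that more compound is needed for the effect:

Compound 1 `CC(=O)c1cccc(-c2ccc(C(=O)N(Cc3cccc(OCCCCCC(=O)O)c3)C(C)C)cc2)c1`: > 26000 nM (a limit of the assay, not a number)
Compound 2 `CC(C)N(Cc1cccc(OCCCCCC(=O)O)c1)C(=O)c1ccc(-c2ccco2)cc1`: > 26000 nM (a limit of the assay, not a number)
Compound 3 `CC(C)N(Cc1cccc(OCCCCCC(=O)O)c1)C(=O)c1ccc(-c2cccc(OC(F)(F)F)c2)cc1`: > 26000 nM (a limit of the assay, not a number)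

Compound 2 therefore stands at a limit in this assay, with no number behind it. Among the measured compounds shown here, nothing among the measured steps can be read: a step that the two limits leave unreadable from compound 1 to compound 2, a step that the two limits leave unreadable from compound 1 to compound 3 and a step that the two limits leave unreadable from compound 2 to compound 3 are all unreadable because of the limit of > 26000 nM in this assay, at which 3 of the 3 values shown sit. The three measured steps all alter the aryl group on the shared core and say nothing about the acid end of the chain.

Compound 4 `CCOC(=O)CCCCCOc1cccc(CN(C(=O)c2ccc(-c3ccco3)cc2)C(C)C)c1` differs from compound 2 by ethyl in place of hydrogen on an oxygen next to a carbonyl group. For the measured compounds named here, no measured step bears on this change, so there is no basis for expecting a move in either direction, and the only anchor is the limit at which compound 2 sits. The expectation for compound 4 is thus a value at or beyond the same limit, an estimated step of a number no higher from compound 2 to compound 4 (the limit leaves the size open) from compound 2. Compound 4 is estimated at 26000 nM, with a range of 13000 nM to 60000 nM, and most likely reported only as a limit in this assay.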

Compound 4, half-maximal effective concentration: > 26000 nM
Compound 4: no number, only a limit; the forecaster's own chance of this, stated with the estimate: 80%; the middle value lies on the limit itself.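

The step from carboxy to ethoxycarbonyl between compound 2 and compound 4 cannot be read, because both compounds stand at the same limit, not a number, in this assay: the limit of > 26000 nM in this assay, at which 4 of the 4 values shown sit.

The compounds shown leave open how far any of them lies beyond this limit, and whether any change to the shared core or chain gives a readable number in this assay.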